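The source may hold more compounds than are shown below. What is called first, only, known or untested is meant among the compounds shown, and "the series" means these compounds.

In an ADME assay on EC17 cells (Homo sapiens) for cytotoxicity, read by trypan blue exclusion (on this read-out lower numbers stand for stronger inhibition and higher numbers for weaker inhibition), compound 1 `C=C(CCC1CCCCC1)C(O)Cc1c(O)cc(C)c(C=O)c1O` gives 87000 nM, the higher of the two numbers that this assay reports. Compound 2 `Cc1cc(O)c(CC(O)C(C)CC[C@H]2[C@@H](C)CCCC2(C)C)c(O)c1C=O` gives 16000 nM, a lower number. For compound 3 `C=C(C)C(O)Cc1c(O)cc(C)c(C=O)c1O` this assay reports only a limit, > 130000 nM. Among the measured compounds shown here, the one measured step in one place, an at least 1.4-fold higher number from compound 1 to compound 3 (0.17 log units; that floor lies within the scatter), bears on (the limit of > 130000 nM in this assay, at which 1 of the 3 values shown sits).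

Compound 4 `C=C(CCc1c(C)cccc1C)C(O)Cc1c(O)cc(C)c(C=O)c1O` differs from compound 1 by 2,6-dimethylphenyl in place of cyclohexyl on a saturated chain carbon, two bonds along the chain from a double-bonded chain carbon. The measured step, from compound 1 to compound 3, removed the whole cyclohexylmethyl and moved the number up by no more than the scatter allows one to tell; the change to compound 4 keeps a ring of similar size at that chain carbon, so no step beyond the scatter is expected. Compound 4 is therefore estimated at 80000 nM (35000 nM to 180000 nM), a step of a 1.1-fold lower number from compound 1 to compound 4 (0.04 log units; within the scatter).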

Compound 4, half-maximal inhibitory concentration: 45000 nM
The estimate for compound 4 lay 1.8-fold (0.25 log units) above the measured number; the range from low to high includes it.
By their numbers in this assay, from the lowest: compound 2; then compounds 4 and 1 (each within the scatter of the next). At a limit, above all of these: compound 3.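

In this assay, 2,6-dimethylphenyl in place of cyclohexyl gives a 1.9-fold lower number from compound 1 to compound 4 (0.29 log units; within the scatter) and so leaves the two compounds within the scatter of each other. At this saturated chain carbon, an aromatic ring carrying two methyl groups therefore cannot be told apart from a non-aromatic carbon ring, whereas the earlier step took away the whole cyclohexylmethyl. Nothing measured here accounts for the size of this step. Going by these compounds, what an amine or a carboxylic acid would do at this chain carbon stays open, as does a plain phenyl ring without the two methyl groups.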